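The source may report more compounds than this note shows. Statements on the series, on what has been measured and on what is new or still open speak of the compounds shown alone.

Measured in a physicochemical assay for lipophilicity, measured as octanol-water partition; a higher number here means a more lipophilic compound, a lower number a more polar compound:

- Compound 1 `COC(=O)c1cn(C/C=C(/C)CC/C=C(\C)CCC=C(C)C)nn1`: 5.25
- Compound 2 `CCCCCc1cn(C/C=C(/C)CCC=C(C)C)nn1`: 5.45

These two values lie within the scatter of each other, so compound 2 shares the top of this short series with compound 1. The next compound to be measured is compound 3 `COC(=O)c1cn(C/C=C(/C)CCC=C(C)C)nn1`, which has methoxycarbonyl in place of pentyl on an aromatic carbon. Among the compounds with values here, no measured pair isolates this swap, so the size of the step has to be judged from the structures. Compound 1 also carries methoxycarbonyl, yet its value of 5.25 comes with a longer chain on the shared core, so it is only a loose guide. A clear fall in this assay, well beyond the scatter, is expected, and the estimated change is a number 1.65 log units lower from compound 2 to compound 3 (beyond the scatter). The estimate for compound 3 is 3.8, with an expected range of 3.3 to 4.3.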

Compound 3, partition coefficient: 3.2
For compound 3 the middle estimate is 0.60 log units above the measured one, outside the stated range (below it).
By their numbers in this assay, from the lowest: compound 3; then compounds 1 and 2 (each within the scatter of the next).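

In this assay, methoxycarbonyl in place of pentyl on an aromatic carbon gives a number 2.25 log units lower from compound 2 to compound 3 (beyond the scatter), so this position of the shared core can shift the read-out strongly. With methoxycarbonyl kept on that carbon, hydrogen in place of 3-methylbut-2-en-1-yl on a saturated chain carbon bound to a double-bonded chain carbon gives a number 2.05 log units lower from compound 1 to compound 3 (beyond the scatter), a second large step from a change in a different place. Nothing available explains the size of either step.

On these data alone, it remains open where an amine, a carboxylic acid or a propyl chain on the aromatic carbon would fall relative to pentyl and methoxycarbonyl. As far as these compounds go, it is also open whether adding 3-methylbut-2-en-1-yl to the chain would produce a similar step in a compound carrying pentyl rather than methoxycarbonyl.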